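Oxime ether series: nitro replaced by methyl on the benzyl ring

The source may hold more compounds than are shown below. What is called first, only, known or untested is meant among the compounds shown, and "the series" means these compounds.

compound 1 `Cc1ccc(CO/N=C/c2c(C)nn(C)c2Oc2ccc(Cl)cc2)cc1` gives 50%
compound 2 `Cc1nn(C)c(Oc2ccccc2)c1/C=N/OCc1ccc([N+](=O)[O-])cc1` gives 39.4%

Both numbers come from a functional assay on A549 cells (Homo sapiens) for antiproliferative activity, tested at 1 uM; a higher number here means more inhibition at the concentration tested (going by the name of the read-out), a lower number less inhibition. Compound 2 stands lowest of the two; compound 1 sits higher by a margin beyond the usual scatter. Within the data shown here, no pair of measured compounds differs in a single place, so no step within the measured set can be used to calibrate a single substitution.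

Compound 3 `Cc1ccc(CO/N=C/c2c(C)nn(C)c2Oc2ccccc2)cc1` is the next to be measured. Its difference from compound 2 is counted as follows:

methyl in place of nitro on an aromatic carbon

The group leaving is nitro, the group entering is methyl, at an aromatic carbon of a six-membered aromatic ring of carbon only, para to a large group; cut one bond further out, 4-nitrophenyl becomes 4-methylphenyl.

Compound 1 carries a methyl at the corresponding place and gives 50% in this assay, but its ether ring differs from that of compound 3, so it is only a loose guide. A modest upward step is expected, a number 5.6 percentage points higher from compound 2 to compound 3 (within the scatter), likely within or just beyond the scatter. Compound 3 is therefore estimated at 45%, within a range of 27% to 63%.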

Compound 3, a percentage reported as inhibition, at one concentration (the size of the read-out at that concentration, not a potency): 29.1%
Compound 3: the middle estimate sits 15.9 percentage points above what was measured, and the stated range covers the measured number.
By their numbers in this assay, from the lowest: compound 3; then compound 2; then compound 1.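

In this assay methyl in place of nitro, on an aromatic carbon para to a large group, gives a number 10.3 percentage points lower from compound 2 to compound 3 (beyond the scatter) and so shows that this position responds to the change, with 4-nitrophenyl holding more inhibition than 4-methylphenyl on the core of compound 3. Among these compounds, compound 3 also supplies the first single-place comparison at the chloro position, where hydrogen in place of chloro on an aromatic carbon gives a number 20.9 percentage points lower from compound 1 to compound 3 (beyond the scatter) and places compound 3 lowest of the three, as both steps are beyond the scatter. Nothing on hand accounts for either step.

From the compounds shown here alone, whether nitro and chloro together would hold more inhibition than either alone stays open, since compound 1 and compound 2 differ in two places and their values cannot isolate either change. Also open, going by these compounds, are the parent with hydrogen at the para position of the benzyl ring and other groups there, such as an amine, a methoxy or a carboxylic acid, and whether these steps would hold at other concentrations.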